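Swapping the aryl group on an oxazole ketone fatty-acid amide hydrolase inhibitor

This account rests on a few compounds, and the source may have more. Where it says the series, first, only, none or still open, it means among the compounds named here.

Measured compounds:
compound 1 `O=C(O)c1ccc(-c2cnc(C(=O)CCCCCCc3ccccc3)o2)cc1`, 60 nM
compound 2 `Cc1cccc(-c2cnc(C(=O)CCCCCCc3ccccc3)o2)n1`, 3.3 nM
compound 3 `NC(=O)c1cccc(-c2cnc(C(=O)CCCCCCc3ccccc3)o2)n1`, 1 nM

In an assay (Rattus norvegicus) for inhibition of Fatty-acid amide hydrolase 1 (Homo sapiens) (on this read-out higher numbers stand for weaker inhibition and lower numbers for stronger inhibition), compound 3 gives the lowest number of the three, with compound 2 nearest to it (a 3.3-fold lower number from compound 2 to compound 3 (0.52 log units; beyond the scatter)) and compound 1 furthest (a 60-fold lower number from compound 1 to compound 3 (1.78 log units; beyond the scatter)). Compound 4 `O=C(CCCCCCc1ccccc1)c1ncc(-c2cncnc2)o1` differs from compound 3 in one place: pyrimidin-5-yl in place of 6-carbamoylpyridin-2-yl on an aromatic carbon. Among the measured compounds shown here, no measured step matches this change directly. The closest guide is the modest step of a 3.3-fold lower number from compound 2 to compound 3 (0.52 log units; beyond the scatter), which shows what the carbamoyl contributes; compound 4 lacks it, and its ring differs further. A step back toward higher numbers is therefore expected, larger than the modest one seen, though far short of the large step of a 60-fold lower number from compound 1 to compound 3 (1.78 log units; beyond the scatter). For compound 4 the expected result is 25 nM, with a plausible range of 6 nM to 100 nM, meaning an expected step of a 25-fold higher number from compound 3 to compound 4 (1.40 log units; beyond the scatter).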

Compound 4, inhibition constant: 22 nM
Compound 4: middle estimate off by 1.1-fold (0.06 log units), on the high side, and the stated range covers the measured number.
By their numbers in this assay, from the lowest: compound 3; then compound 2; then compound 4; then compound 1.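

In this assay, a ring with no added group at this position still gives a fair result, but it does not match the substituted pyridines: a 22-fold higher number from compound 3 to compound 4 (1.34 log units; beyond the scatter) and a 6.7-fold higher number from compound 2 to compound 4 (0.82 log units; beyond the scatter). It does, however, beat the 4-carboxyphenyl group, with a 2.7-fold lower number from compound 1 to compound 4 (0.44 log units; beyond the scatter). No evidence here explains this order. On these data alone, compound 4 changes both the ring and its added group, so their separate shares remain open. A bare pyridin-2-yl ring, or a pyrimidin-5-yl ring carrying a carbamoyl or an amine, could separate them.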